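A Methyl Step Repeated on a Second Core

The compounds below may be only part of what the source reports. "The series", "measured", "known", "first", "only" and "open" are said of these compounds alone.

Measured so far:
compound 1 `COc1cc(CC(O)(COCc2ccccc2)COCc2ccccc2)nc(OC)n1` — > 100000 nM (a limit of the assay)
compound 2 `COc1nc(CC(O)(COCc2ccccc2)COCc2ccccc2)c(C)c(OC)n1` — 3500 nM
compound 3 `C[Si](C)(C)CCOCn1c(CC(O)COCc2ccccc2)cc(=O)[nH]c1=O` — > 100000 nM (a limit of the assay)

In a functional assay on SW-620 cells (Homo sapiens) for antiproliferative activity, read by MTT assay, with a stated time of 72 h (a lower number here means a stronger inhibitor, a higher number a weaker inhibitor), compound 1 gives > 100000 nM, which is a limit of the assay. Compound 2 gives 3500 nM. The change between them is methyl in place of hydrogen on an aromatic carbon, and it produced an at least 28-fold lower number from compound 1 to compound 2 (1.45 log units; beyond the scatter). Compound 3 gives > 100000 nM, again a limit of the assay; the difference between the core of compound 3 and the core of compound 1 is not broken down here. Compound 4 `Cc1c(CC(O)COCc2ccccc2)n(COCC[Si](C)(C)C)c(=O)[nH]c1=O` differs from compound 3 by methyl in place of hydrogen on an aromatic carbon. Among the compounds with values here, this is the same kind of change as the one from compound 1 to compound 2, not the same: in compound 2 the place is ortho to a methoxy group and para to a methoxy group, whereas in compound 4 it is ortho to a group of 1 heavy atom, meta to a group of 8 heavy atoms, and para to a group of 1 heavy atom. Note (the limit of > 100000 nM in this assay, at which 2 of the 3 values shown sit). Compound 4 is expected to show an at least 5.0-fold lower number from compound 3 to compound 4 (0.69 log units; beyond the scatter), resting on the earlier step of an at least 28-fold lower number from compound 1 to compound 2 (1.45 log units; beyond the scatter) together with the limit of compound 3 > 100000 nM. Compound 4 is therefore estimated at 20000 nM, expected between 4000 nM and 100000 nM.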

Compound 4, half-maximal inhibitory concentration: > 100000 nM
Compound 4: only a limit was reported; the forecaster's own chance of this, stated with the estimate: 40%; middle value at least 5.0-fold (0.69 log units) from the limit.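

In this assay compound 4 gives > 100000 nM, a limit of the assay. Within the data shown here, compound 3 also rests on a limit, so no step between compound 3 and compound 4 can be read. The compounds shown leave open whether methyl in place of hydrogen on an aromatic carbon lowers the number on the core of compound 3, as it did on the core of compound 1.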